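Shifting a Methoxy Group: Expected Clearance of Compound 4

This account rests on a few compounds, and the source may have more. Where it says the series, first, only, none or still open, it means among the compounds named here.

Of the compounds shown here, three have been measured in an ADME assay on microsomes from liver (Homo sapiens) for metabolic stability, tested at 2.5 uM; on this read-out higher numbers stand for fast clearance and lower numbers for slow clearance. Compound 1 `O=S(=O)(c1ccc(F)c(F)c1)c1cnc2cc(F)ccc2c1-c1ccc(Cl)cc1` gives 0.01 mL/min; compound 2 `COc1cccc(-c2c(S(=O)(=O)c3ccc(C)c(C)c3)cnc3cc(F)ccc23)c1` gives 8.78 mL/min; compound 3 `COc1ccc(-c2c(S(=O)(=O)c3ccc(F)c(F)c3)cnc3cc(F)ccc23)cc1` gives 1.1 mL/min. Compound 3 thus stands second highest of the three: compound 2 lies above it and compound 1 far below it. Among the measured compounds shown here, the only single-change step recorded, a 110-fold higher number from compound 1 to compound 3 (2.04 log units; beyond the scatter), involves methoxy in place of chloro on an aromatic carbon and so says nothing about where a methoxy group sits. Compound 4 `COc1cccc(-c2c(S(=O)(=O)c3ccc(F)c(F)c3)cnc3cc(F)ccc23)c1` differs from compound 3 as follows: 3-methoxyphenyl in place of 4-methoxyphenyl on an aromatic carbon. For the measured compounds named here, no measured step matches this change. Compound 2 carries the 3-methoxyphenyl group that enters here, but it also differs from compound 3 in a second place, so its higher value in this assay can only hint at the direction. On that basis a modest rise in this assay is expected for compound 4, amounting to a 2.3-fold higher number from compound 3 to compound 4 (0.36 log units; beyond the scatter). Compound 4 is therefore estimated at 2.5 mL/min, with a range from 0.8 mL/min to 8 mL/min.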

Compound 4, intrinsic clearance in a liver preparation (reported as CLH), per the amount of preparation that the assay uses: 1.77 mL/min
Estimate against measurement, compound 4: 1.4-fold (0.15 log units) above; the measured number falls inside the stated range.
By their numbers in this assay, from the lowest: compound 1; then compounds 3 and 4 (each within the scatter of the next); then compound 2.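

In this assay, 3-methoxyphenyl in place of 4-methoxyphenyl on this aromatic carbon gives a 1.6-fold higher number from compound 3 to compound 4 (0.21 log units; within the scatter), so the two methoxy placements cannot be told apart here. Among the compounds shown here, with 3-methoxyphenyl held constant, 3,4-difluorophenyl in place of 3,4-dimethylphenyl on the sulfonyl sulfur gives a 5.0-fold lower number from compound 2 to compound 4 (0.70 log units; beyond the scatter), which is the first single-place reading of that group and shows that the sulfonyl substituent matters more here than the methoxy placement. 3-Methoxyphenyl in place of 4-chlorophenyl gives a 180-fold higher number from compound 1 to compound 4 (2.25 log units; beyond the scatter), so the large step first seen with 4-methoxyphenyl holds for both methoxy placements.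

Nothing at hand explains any of these differences. Going by these compounds, whether a longer alkoxy chain, a hydroxy group or an amine on this phenyl ring would give a number like those of the two methoxy compounds stays open.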